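A Dichlorobenzyl Urea Replaces a Methylpiperazine Amide

The source may report more compounds than this note shows. Statements on the series, on what has been measured and on what is new or still open speak of the compounds shown alone.

Of the compounds shown here, three have been measured in an assay on CHO cells for displacement of a labelled ligand from histamine receptor H3 (Macaca mulatta), read by scintillation counting, with a stated time of 1 h; a higher number here means a weaker inhibitor, a lower number a stronger inhibitor. Compound 1 `CC1CCCN1C1CCN(c2ccc(NC(=O)Nc3cc(Cl)cc(Cl)c3)cc2)C1` gives 19.1 nM. Compound 2 `Cc1cc(N2CCC(N3CCCC3C)C2)ccc1NC(=O)N1CCN(C)CC1` gives 10.5 nM. Compound 3 `Cc1cc(NC(=O)N2CCN(C)CC2)ccc1N1CCC(N2CCCC2C)C1` shares its methyl-bearing aromatic ring and its methylpyrrolidine-substituted pyrrolidine with compound 2. In this assay compound 3 gives 12.7 nM. On these numbers compound 3 stands second highest of the three, and all three values sit within the scatter of one another, so none of them can be called stronger or weaker than the rest.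

Compound 4 `Cc1cc(NC(=O)NCc2cc(Cl)cc(Cl)c2)ccc1N1CCC(N2CCCC2C)C1` has not yet been measured. It differs from compound 3 in one place: (3,5-dichlorobenzyl)amino in place of 4-methylpiperazin-1-yl on a carbonyl carbon. The urea carbonyl and the amide-type nitrogen on the aromatic ring stay as they are.

Within the data shown here, no pair of measured compounds shows this step directly, so the expectation has to lean on the closest analogue of compound 4 in the part that changes, namely compound 1, which gives 19.1 nM in this assay. On that basis the step from compound 3 to compound 4 is expected to be small, a 1.6-fold higher number from compound 3 to compound 4 (0.20 log units; within the scatter), and in the direction of a slightly higher number, likely within the scatter. Compound 4 is therefore expected to give about 20 nM, with a range from 6 nM to 65 nM.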

Compound 4, inhibition constant: 28.8 nM
For compound 4 the middle estimate is 1.4-fold (0.16 log units) below the measured one, within the range that was stated.
By their numbers in this assay, from the lowest: compounds 2, 3, 1 and 4 (each within the scatter of the next, the first and the last beyond it).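

In this assay, among these compounds, putting (3,5-dichlorobenzyl)amino in place of 4-methylpiperazin-1-yl on the carbonyl carbon gives a 2.3-fold higher number from compound 3 to compound 4 (0.36 log units; beyond the scatter), the first change here whose size can be read directly, and it is modest but beyond the scatter. This position therefore accepts a very different group with only a modest shift in the number: a non-aromatic ring with two hetero atoms leaves, and a carbon-only aromatic ring with a hydrogen-bond donor enters. The swap changes several features at once, and nothing measured here links the shift to any one of them.

The compounds shown leave open which part of the entering group matters: the nitrogen with its hydrogen, the benzyl carbon, the aromatic ring or the two chlorines. Plain benzylamino on the same carbonyl carbon would test the chlorines, while morpholin-4-yl or dimethylamino would show how much of the value of compound 3 depends on the 4-methylpiperazin-1-yl group itself.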